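Swapping the aryl group of compound 1

The compounds below may be only part of what the source reports. "The series", "measured", "known", "first", "only" and "open" are said of these compounds alone.

Within the data shown here, compound 1 `CC(C)(C)n1ncc(OCc2nnc(-c3ccc(Br)cc3)o2)c(Cl)c1=O` has the lower of the two numbers so far in a functional assay on the whole organism for inhibition, with Mythimna separata as the target, with a stated time of 5 days; on this read-out lower numbers stand for an effect already at smaller amounts and higher numbers for an effect only at larger amounts of compound: compound 1 gives 21.4 ug/mL, while compound 2 `CCCCn1ncc(OCc2nnc(-c3ccc(F)cc3)o2)c(Cl)c1=O` gives 162 ug/mL, a gap beyond the usual scatter. These two compounds differ in more than one place, so the gap cannot be pinned on any single group. The next compound, compound 3 `CC(C)(C)n1ncc(OCc2nnc(-c3cc(F)c(F)cc3F)o2)c(Cl)c1=O`, keeps the core of compound 1 but has 2,4,5-trifluorophenyl in place of 4-bromophenyl on an aromatic carbon. Among the measured compounds shown here, no measured pair shows this swap alone, so any expectation stays loose. Compound 2, which also carries fluorine on its aryl group, reads 162 ug/mL, a weak hint towards a higher number. The expected change is a modest rise, a 2.3-fold higher number from compound 1 to compound 3 (0.37 log units; beyond the scatter). For compound 3 the estimated value is 50 ug/mL, with an expected range of 15 ug/mL to 160 ug/mL.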

Compound 3, half-maximal effective concentration: 75.7 ug/mL
Beside the measured number, compound 3's estimate is 1.5-fold (0.18 log units) below it; measured number inside the range.
By their numbers in this assay, from the lowest: compound 1; then compound 3; then compound 2.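

Among these compounds, this is the first pair that differs in one place only, so the aryl group on the five-membered aromatic ring with 2 nitrogen and 1 oxygen can now be judged on its own: in this assay, 2,4,5-trifluorophenyl in place of 4-bromophenyl gives a 3.5-fold higher number from compound 1 to compound 3 (0.55 log units; beyond the scatter) on the core of compound 1. The read-out therefore responds to a change at this position, although the step is modest and 4-bromophenyl gives the lower number of the two. No measurement here explains why the number rises.

Among the compounds shown here, with only two aryl groups compared on this core, the pair cannot separate the loss of bromine from the gain of fluorine. A plain phenyl or a 4-chlorophenyl group on the same core would help to tell these apart.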